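Aryl exchange on the saturated ring carbon

The source may report more compounds than this note shows. Statements on the series, on what has been measured and on what is new or still open speak of the compounds shown alone.

In a functional assay on MDA-MB-468 cells (Homo sapiens) for antiproliferative activity, read by CellTiter-Glo, with a stated time of 96 h (a lower number here means a stronger inhibitor, a higher number a weaker inhibitor), compound 1 `COc1ccc(-c2nsc3c2NC(=O)CC3c2cccc(OC)c2)cc1` gives 662 nM and compound 2 `COc1ccc(-c2nsc3c2NC(=O)CC3c2cccc(Cl)c2)cc1` gives 752 nM, which places compound 2 within the scatter of compound 1. Compound 3 `COc1ccc(-c2nsc3c2NC(=O)CC3c2ccc(F)cc2)cc1` differs from compound 2 by 4-fluorophenyl in place of 3-chlorophenyl on a saturated ring carbon, with 4-fluorophenyl in place of 3-chlorophenyl on a saturated ring carbon. Among the compounds with values here, the only measured step, a 1.1-fold higher number from compound 1 to compound 2 (0.06 log units; within the scatter), exchanges chloro for methoxy on an aromatic carbon and stays within the scatter. Within the data shown here, no measured pair tests fluoro on this ring, so the range is kept wide. In this assay the expected change is a 1.1-fold higher number from compound 2 to compound 3 (0.05 log units; within the scatter), not beyond the scatter. For compound 3 the estimate is 850 nM, with an expected range of 350 nM to 2100 nM.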

Compound 3, half-maximal inhibitory concentration: 1850 nM
Estimate against measurement, compound 3: 2.2-fold (0.34 log units) below; low and high end bracket the measured number.
By their numbers in this assay, from the lowest: compounds 1 and 2 (each within the scatter of the next); then compound 3.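

In this assay this position is not indifferent to the aryl group: the change to 4-fluorophenyl gives a 2.5-fold higher number from compound 2 to compound 3 (0.39 log units; beyond the scatter) and a 2.8-fold higher number from compound 1 to compound 3 (0.45 log units; beyond the scatter), both beyond the scatter, whereas the earlier exchange of 3-methoxyphenyl for 3-chlorophenyl stayed within it. Here the halogen and its place on the phenyl ring change in one step, so the two effects cannot be separated. An unsubstituted phenyl or a pyridine ring on this saturated ring carbon remains open, and no evidence available here accounts for the step.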